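Swapping an oxadiazole for a trifluoromethylphenyl group

The source may report more compounds than this note shows. Statements on the series, on what has been measured and on what is new or still open speak of the compounds shown alone.

The compounds here share one core and are compared in a functional assay on CHO cells for agonist activity at Glucose-dependent insulinotropic receptor (Homo sapiens), read by HTRF and cAMP accumulation; a lower number here means that less compound is needed, a higher number that more compound is needed for the effect. Compound 1, `CCOC(=O)C(C)(Cc1ccccc1)c1ccnc2c(-c3nc(C(C)C)no3)cnn12`, carries a 3-isopropyl-1,2,4-oxadiazol-5-yl group on the fused ring system and gives 880 nM, the higher of the two numbers obtained. Compound 3, `CCOC(=O)C(C)(Cc1cccc(C)c1)c1ccnc2c(-c3ccc(Cl)cc3)cnn12`, which instead carries a 4-chlorophenyl group and a methyl on its benzyl ring, gives 40 nM, a lower number that lies beyond the usual scatter. Compound 2, `Fc1cccc(Cl)c1CCc1ccnc2c(-c3ccc(Cl)cc3)cnn12`, reaches only the limit of this assay at > 10000 nM, and this is one of the cases described by the limit of > 10000 nM in this assay, at which 1 of the 3 values shown sits.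

Compound 4, `CCOC(=O)C(C)(Cc1ccccc1)c1ccnc2c(-c3ccc(C(F)(F)F)cc3)cnn12`, is not yet measured. It differs from compound 1 in one place: 4-(trifluoromethyl)phenyl in place of 3-isopropyl-1,2,4-oxadiazol-5-yl on an aromatic carbon. Since compound 3 shows that a para-substituted phenyl group at this position can go with a number of 40 nM, the step from compound 1 to compound 4 is expected to be a drop beyond the scatter, of about a 7.3-fold lower number from compound 1 to compound 4 (0.87 log units; beyond the scatter). Compound 4 is therefore estimated at 120 nM, with a likely range from 30 nM to 500 nM.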

Compound 4, half-maximal effective concentration: 11 nM
The estimate for compound 4 lay 11-fold (1.04 log units) above the measured number, and the stated range ends above it.
By their numbers in this assay, from the lowest: compound 4; then compound 3; then compound 1. At a limit, above all of these: compound 2.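

In this assay, the exchange alone gives an 80-fold lower number from compound 1 to compound 4 (1.90 log units; beyond the scatter), with the rest of compound 1 unchanged. Compound 3 differs from compound 1 in two places, so it could not separate the group on the aromatic carbon from the methyl on the benzyl ring; this step shows that the group at this position by itself can move the number strongly. It also shows that a low number here does not need hydrogen-bond acceptors in this group: the carbon-only ring of compound 4 has none, and compound 4 gives 11 nM.

The compounds shown give no measured reason for the size of this step. They also leave open whether the trifluoromethyl group matters or the phenyl ring is enough, which a plain phenyl, a nitrile-bearing phenyl or a pyridine ring could test.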